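A Nitrile Gives Way to a Tetrazole

The compounds below may be only part of what the source reports. "The series", "measured", "known", "first", "only" and "open" are said of these compounds alone.

Of the compounds shown here, three sharing one core have been measured in an assay for inhibition of Fatty-acid amide hydrolase 1 (Rattus norvegicus); on this read-out higher numbers stand for weaker inhibition and lower numbers for stronger inhibition. Compound 1 `CN(C)C(=O)c1cnc(C(=O)CCc2ccc(-c3ccccc3)cc2)o1` gives 3 nM, compound 2 `N#Cc1cccc(-c2cnc(C(=O)CCc3ccc(COc4ccccc4)cc3)o2)n1` gives 0.56 nM, and compound 3 `COC(=O)c1ccc(-c2cnc(C(=O)CCc3ccc(Oc4ccccc4)cc3)o2)nc1` gives 54 nM. Compound 2 thus stands lowest of the three, with compound 1 nearest to it and compound 3 furthest away, both of these gaps lying beyond the usual scatter.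

Compound 4 `O=C(CCc1ccc(COc2ccccc2)cc1)c1ncc(-c2cccc(-c3nnn[nH]3)n2)o1` has not yet been measured. It differs from compound 2 in a single place: 1H-tetrazol-5-yl in place of cyano on an aromatic carbon. In words, a 1H-tetrazol-5-yl group takes the place of the cyano group on an aromatic carbon.

Among the measured compounds shown here, no pair of measured compounds shows this same exchange, so the size of the step cannot be read off from the known numbers. The change keeps the rest of the molecule, including the part that carries the phenoxymethyl group, unchanged. A modest step toward weaker inhibition, a 3.6-fold higher number from compound 2 to compound 4 (0.55 log units; beyond the scatter), is expected. Compound 4 is therefore estimated to give 2 nM in this assay, within a range from 0.4 nM to 10 nM.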

Compound 4, inhibition constant: 21 nM
Beside the measured number, compound 4's estimate is 11-fold (1.02 log units) below it; measured number outside the range, above it.
By their numbers in this assay, from the lowest: compound 2; then compound 1; then compound 4; then compound 3.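

Replacing 6-cyanopyridin-2-yl with 6-(1H-tetrazol-5-yl)pyridin-2-yl brings a 38-fold higher number from compound 2 to compound 4 (1.57 log units; beyond the scatter) in this assay, so this place, next to the ring nitrogen, does not treat the two groups alike. Among the compounds shown here, this is the first single change, and it shows how far one group at this place can move the number. The exchange adds a five-membered aromatic ring and a hydrogen-bond donor together, so the step cannot be assigned to either one, and nothing measured here explains it.

On these data alone, whether a carboxylic acid or a primary amide at this place would give a number closer to that of the cyano group or the 1H-tetrazol-5-yl group stays open. Also open, as far as these compounds go, is whether the same exchange would move the number as far with another group in place of phenoxymethyl.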